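The compounds below may be only part of what the source reports. "The series", "measured", "known", "first", "only" and "open" are said of these compounds alone.

In a functional assay on RAW264.7 cells (Mus musculus) for inhibition, read by Griess assay, with stated times of 3 h and 24 h (on this read-out lower numbers stand for stronger inhibition and higher numbers for weaker inhibition), three compounds have been measured. Compound 1 `C=C1CC[C@H]2[C@@](C)(CCC(=O)N[C@@]2(C)COC(=O)c2ccccc2)[C@@H]1/C=C/C1=CCOC1=O` gives > 50000 nM, which is a limit of the assay and not a number. Compound 2 `C=C1CC[C@H]2[C@@](C)(CCC(=O)N[C@@]2(C)COC(=O)c2ccc([N+](=O)[O-])cc2)[C@@H]1/C=C/C1=CCOC1=O` gives 33500 nM. Compound 3 `C=C1CC[C@H]2[C@@](C)(CC[C@@H](OC(=O)c3cccnc3)[C@@]2(C)NC=O)[C@@H]1/C=C/C1=CCOC1=O` gives > 50000 nM, which is likewise only a limit. The set therefore stands largely at the limit of > 50000 nM in this assay, at which 2 of the 3 values shown sit.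

Compound 4 `C=C1CC[C@H]2[C@@](C)(CC[C@@H](OC(=O)[C@H]3CCCN3)[C@@]2(C)NC=O)[C@@H]1/C=C/C1=CCOC1=O` has not yet been measured. It differs from compound 3 by pyrrolidin-2-yl in place of pyridin-3-yl on a carbonyl carbon, in words pyrrolidin-2-yl in place of pyridin-3-yl on a carbonyl carbon. Among the measured compounds shown here, the only measured step is an at least 1.4-fold lower number from compound 1 to compound 2 (0.17 log units; that floor lies within the scatter). That step concerns nitro in place of hydrogen on an aromatic carbon, not the group changed here, so it bears on this change only loosely. For the measured compounds named here, no measured step tests the replacement itself, and compound 3 offers no number to start from. A shift beyond the scatter is therefore not expected. The expected step is an at least 1.2-fold lower number from compound 3 to compound 4 (0.09 log units; that floor lies within the scatter). The estimated value for compound 4 is 40000 nM, with an expected range from 15000 nM to 60000 nM.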

Compound 4, half-maximal inhibitory concentration: > 50000 nM
Compound 4: no number, only a limit; the forecaster's own chance of this, stated with the estimate: 55%; middle value at least 1.2-fold (0.09 log units) from the limit.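

Compound 4 gives > 50000 nM, which is a limit and not a number. Among the compounds shown here, compound 3 is likewise only a limit, and no step from compound 3 to compound 4 can be read. The compounds shown leave open whether pyrrolidin-2-yl and pyridin-3-yl on a carbonyl carbon differ at all in inhibition.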